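The compounds below may be only part of what the source reports. "The series", "measured", "known", "first", "only" and "open" are said of these compounds alone.

In an assay on mitochondria from L6 cells (Rattus norvegicus) for activation, with a stated time of 90 min (on this read-out higher numbers stand for an effect only at larger amounts of compound and lower numbers for an effect already at smaller amounts), compound 1 `Oc1nc2nonc2nc1Nc1ccc(OCc2ccccc2)cc1` gives 2400 nM, compound 2 `CCCCc1ccc(Nc2nc3nonc3nc2O)cc1` gives 2100 nM, and compound 3 `CCCCc1ccc(Nc2nc3nonc3nc2O)c(F)c1` gives 1100 nM. Compound 2 therefore holds the second highest of the three numbers: its nearest neighbour is reached by a 1.1-fold lower number from compound 1 to compound 2 (0.06 log units; within the scatter), its furthest by a 1.9-fold lower number from compound 2 to compound 3 (0.28 log units; within the scatter). Compound 4 `Oc1nc2nonc2nc1Nc1ccc(OC(F)F)cc1` differs from compound 2 by difluoromethoxy in place of butyl on an aromatic carbon. The step that bears on this exchange at the same place is a 1.1-fold lower number from compound 1 to compound 2 (0.06 log units; within the scatter), which stayed inside the usual spread; the step of a 1.9-fold lower number from compound 2 to compound 3 (0.28 log units; within the scatter) concerns another place and also stayed inside it. A step no larger than the scatter is accordingly expected, a 1.1-fold lower number from compound 2 to compound 4 (0.02 log units; within the scatter). Compound 4 is estimated at 2000 nM in this assay, between 900 nM and 4500 nM.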

Compound 4, half-maximal effective concentration: 20600 nM
The estimate for compound 4 lay 10-fold (1.01 log units) below the measured number; the measured number lies above the stated range.
By their numbers in this assay, from the lowest: compounds 3, 2 and 1 (each within the scatter of the next, the first and the last beyond it); then compound 4.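

In this assay, going by these compounds alone, difluoromethoxy is the first group at this aromatic carbon to move the number beyond the scatter, with a 9.8-fold higher number from compound 2 to compound 4 (0.99 log units; beyond the scatter) and an 8.6-fold higher number from compound 1 to compound 4 (0.93 log units; beyond the scatter). Butyl and difluoromethoxy both count 4 heavy atoms, so that count does not separate them, and compound 1 also carries oxygen on the ring yet stays within the scatter of compound 2. Nothing measured here explains the step. As far as these compounds go, whether the fluorines matter stays open: methoxy or trifluoromethoxy at this place would speak to that.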